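Methylamino for Isopropyl in Compound 4

The compounds below may be only part of what the source reports. "The series", "measured", "known", "first", "only" and "open" are said of these compounds alone.

Compound 2 `CC(C)C(=O)NCCS(=O)(=O)NC(=O)c1ccc(Nc2nc(NC3(c4ccc(Cl)cc4)CC3)nc(OCC(F)(F)F)n2)cc1` stands lowest of three in an ADME assay on microsomes from liver (Rattus norvegicus) for metabolic stability, with a stated time of 10 min (a higher number here means that more of the compound is left, a lower number that less of the compound is left), where compound 2 gives 84%. Compound 1 `O=C(NS(=O)(=O)c1ccc(F)cc1)c1ccc(Nc2nc(NC3(c4ccc(Cl)cc4)CC3)nc(OCC(F)(F)F)n2)cc1` gives 99%, and compound 3 `CC(C)(C)CNCCS(=O)(=O)NC(=O)c1ccc(Nc2nc(NC3(c4ccc(Cl)cc4)CC3)nc(OCC(F)(F)F)n2)cc1` gives 90%. The step of a number 15 percentage points lower from compound 1 to compound 2 (beyond the scatter) lies beyond the scatter, whereas a number 9 percentage points lower from compound 1 to compound 3 (within the scatter) and a number 6 percentage points higher from compound 2 to compound 3 (within the scatter) do not. Compound 4 `CNC(=O)NCCS(=O)(=O)NC(=O)c1ccc(Nc2nc(NC3(c4ccc(Cl)cc4)CC3)nc(OCC(F)(F)F)n2)cc1` differs from compound 2 as follows: methylamino in place of isopropyl on a carbonyl carbon. Within the data shown here, no measured step alters a group on this carbonyl carbon; the closest comparison, a number 6 percentage points higher from compound 2 to compound 3 (within the scatter), reworks the same side chain and stays within the scatter. The expected step is accordingly no change at the digits printed from compound 2 to compound 4 (within the scatter), none beyond the scatter. Compound 4 is therefore estimated at 84%, between 70% and 95%.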

Compound 4, percent of the compound remaining: 100%
For compound 4 the middle estimate is 16 percentage points below the measured one, outside the stated range (above it).
By their numbers in this assay, from the lowest: compounds 2, 3, 1 and 4 (each within the scatter of the next, the first and the last beyond it).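

On this carbonyl carbon, methylamino in place of isopropyl gives (a number 16 percentage points higher from compound 2 to compound 4 (beyond the scatter)) in (this assay), so the group here does register in the read-out, by a modest step. Against the other two compounds compound 4 stays within the scatter, with (a number 10 percentage points higher from compound 3 to compound 4 (within the scatter)) and (a number 1 percentage points higher from compound 1 to compound 4 (within the scatter)), so the change brings the side chain level with the 4-fluorophenyl of compound 1. No evidence given here accounts for the step. The compounds shown leave open whether dimethylamino or methoxy on this carbonyl carbon would match methylamino. They also leave open whether a longer chain on the urea nitrogen would keep the same number.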